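The compounds below may be only part of what the source reports. "The series", "measured", "known", "first", "only" and "open" are said of these compounds alone.

Compound 1, whose structure is `O=C1NC(=O)/C(=C/c2cn(-c3ccccc3)nc2-c2ccccc2)S1`, is the starting point of this account. In a functional assay on SH-SY5Y cells (Homo sapiens) for inhibition, with stated times of 48 h and 72 h (on this read-out higher numbers stand for weaker inhibition and lower numbers for stronger inhibition), compound 1 carries no single number: its entry reads "not evaluated" (no result reported). A second compound, compound 2 with the structure `O=C1NC(=O)/C(=C/c2cn(-c3ccccc3)nc2-c2ccc(Cl)cc2)S1`, stands in the same position, since in this assay compound 2 is likewise entered as "not evaluated" (no result reported). Within the data shown here, the only measured anchor is compound 3, whose structure is `O=C1NC(=O)/C(=C/c2cn(-c3ccc([N+](=O)[O-])cc3)nc2-c2ccc(Cl)cc2)S1`; in this assay compound 3 gives 2000 nM. Among the measured compounds shown here, because no two measured compounds differ in a single place, no step between measured compounds can be stated, and where compound 1 stands on the numbers is simply unknown.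

The compound to be measured is compound 4, with the structure `C=CCN1C(=O)S/C(=C\c2cn(-c3ccccc3)nc2-c2ccccc2)C1=O`. It differs from compound 1 in one place: allyl in place of hydrogen on an amide-type nitrogen in a ring. For the measured compounds named here, with no step of this kind recorded among the measured compounds, the direction of the change on the half-maximal inhibitory concentration cannot be read from the data; a shift of no more than the usual scatter, in either direction, is the most that can be expected, and the single anchor set by compound 3 at 2000 nM is the only guide to the scale. Compound 4 is therefore expected to give about 3000 nM in this assay, within an estimated range from 800 nM to 12000 nM.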

Compound 4, half-maximal inhibitory concentration: 50000 nM
Beside the measured number, compound 4's estimate is 17-fold (1.22 log units) below it; measured number outside the range, above it.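

With compound 1 carrying no single number in this assay, the step from compound 1 to compound 4 cannot be read, even though compound 4 gives 50000 nM. On these data alone, what allyl in place of hydrogen on the ring nitrogen does to the half-maximal inhibitory concentration stays open. No evidence at hand bears on this result.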